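The source may report more compounds than this note shows. Statements on the series, on what has been measured and on what is new or still open speak of the compounds shown alone.

Measured so far:
compound 1 `CS(=O)(=O)Nc1ccc(Cl)c2c1CCCC2c1c[nH]cn1` — < 10000 nM
compound 2 `CCS(=O)(=O)Nc1cccc(NC2=NCCN2)c1` — < 10000 nM
compound 3 `CCS(=O)(=O)Nc1ccc2c(c1)C(c1c[nH]cn1)CCC2` — 1350 nM

In an assay on isolated protein (Cricetulus griseus) for binding affinity to Alpha-1B adrenergic receptor (Mesocricetus auratus), read by radioligand binding (on this read-out higher numbers stand for weaker inhibition and lower numbers for stronger inhibition), compound 1 gives < 10000 nM, which is a limit of the assay and not a number. Compound 2 likewise gives only a limit, < 10000 nM. Compound 3 gives a measured figure of 1350 nM. Compound 1 therefore stands at the limit of < 10000 nM in this assay, at which 2 of the 3 values shown sit, with no number of its own. Compound 4 `Cc1ccc(NS(C)(=O)=O)c2c1C(c1c[nH]cn1)CCC2` differs from compound 1 by methyl in place of chloro on an aromatic carbon. For the measured compounds named here, no step between measured compounds is available to guide this change, so the expected step is a step that the limit leaves unreadable from compound 1 to compound 4, no larger than the scatter. Compound 4 is accordingly estimated at 3000 nM, with a range from 600 nM to 12000 nM.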

Compound 4, inhibition constant: < 10000 nM
Compound 4: a limit, no number (the forecaster's own chance of this, stated with the estimate: 35%); the middle value is on the limit's open side.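

For the compounds shown here, compound 1 and compound 4 each give only a limit of the assay, and no step between them can be read. The compounds shown leave open whether methyl in place of chloro on an aromatic carbon shifts the affinity at all.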